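Halogen removal on the phenoxy ring: compound 3

The compounds below may be only part of what the source reports. "The series", "measured", "known", "first", "only" and "open" are said of these compounds alone.

The two measured compounds share the core of compound 1 `Cc1nc2ccccc2c(=O)n1/N=C/c1ccc(Oc2ccc(Br)cc2)cc1` and differ only in the halogen on the phenoxy ring. In a physicochemical assay for lipophilicity, in phosphate buffer, measured as octanol-water partition (on this read-out lower numbers stand for lower lipophilicity and higher numbers for higher lipophilicity), compound 1 gives 4.64. Compound 2 `Cc1nc2ccccc2c(=O)n1/N=C/c1ccc(Oc2ccc(F)cc2)cc1` carries fluoro in place of bromo; in this assay compound 2 gives 4.21. For the measured compounds named here, the single measured step, a number 0.43 log units lower from compound 1 to compound 2 (beyond the scatter), is beyond the scatter. Compound 2 therefore stands lowest of the two numbers, with compound 1 as its nearest neighbour and higher beyond the scatter.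

Compound 3 `Cc1nc2ccccc2c(=O)n1/N=C/c1ccc(Oc2ccccc2)cc1` differs from compound 2 by hydrogen in place of fluoro on an aromatic carbon, so the 4-fluorophenoxy group becomes phenoxy. Going by the values given here, only one measured step bears on this change, a number 0.43 log units lower from compound 1 to compound 2 (beyond the scatter), and it exchanged one halogen for another rather than removing one; no measured step removes a halogen outright. On that basis a small further step downward is expected in this assay, namely the estimated step of a number 0.16 log units lower from compound 2 to compound 3 (within the scatter). Compound 3 is estimated at 4.05, with a range from 3.75 to 4.35.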

Compound 3, partition coefficient: 4.01
Beside the measured number, compound 3's estimate is 0.04 log units above it; low and high end bracket the measured number.
By their numbers in this assay, from the lowest: compounds 3 and 2 (each within the scatter of the next); then compound 1.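

In this assay, hydrogen in place of fluoro on this aromatic carbon, para to a large group, gives a number 0.20 log units lower from compound 2 to compound 3 (within the scatter) and so supplies the first measured case of a halogen leaving this position outright, with no separation between the two compounds on this read-out. Hydrogen in place of bromo at the same carbon gives a number 0.63 log units lower from compound 1 to compound 3 (beyond the scatter) and, taken with the earlier bromo-to-fluoro step, this leaves compound 1 as the only one of the three that stands apart, while fluoro and hydrogen cannot be told apart here. No supporting measurement accounts for the size of either step.

Going by these compounds, the three compounds cover only hydrogen, fluoro and bromo at this carbon, so it remains open where chloro, iodo, methyl, methoxy, trifluoromethyl, an amine or a carboxylic acid would fall in this assay. On these data alone, it is also open whether the same exchanges read alike at other carbons of the phenoxy ring, or on a phenoxy ring attached to a different core.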